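Carbonyl substituent swap from compound 3 to compound 4

The compounds below may be only part of what the source reports. "The series", "measured", "known", "first", "only" and "open" are said of these compounds alone.

In a functional assay on A2780 cells (Homo sapiens) for antiproliferative activity, read by CellTiter-Glo, with a stated time of 72 h (on this read-out higher numbers stand for weaker inhibition and lower numbers for stronger inhibition), compound 3 (`C[C@H](NC(=O)[C@@H]1CCCN1C)c1ccc(NC(=O)N2CC(c3cncc(N)c3)C2)cc1`) gives 34 nM, within the scatter of compound 1 (`CCC(=O)N[C@@H](C)c1ccc(NC(=O)N2CC(c3cccnc3)C2)cc1`) at 25 nM, while compound 2 (`C[C@H](NC(=O)C1CCOCC1)c1ccc(NC(=O)N2CC(c3cncc(N)c3)C2)cc1`) gives 500 nM. Compound 4 (`CCC(=O)N[C@@H](C)c1ccc(NC(=O)N2CC(c3cncc(N)c3)C2)cc1`) differs from compound 3 as follows: ethyl in place of 1-methylpyrrolidin-2-yl on a carbonyl carbon. Among the compounds with values here, the one measured step at this place, a 15-fold lower number from compound 2 to compound 3 (1.17 log units; beyond the scatter), is large and shows that the group on this carbonyl carbon can shift the number, but it does not involve ethyl. Compound 1 carries the same ethyl and gives 25 nM, though its structure differs from compound 4 elsewhere. No step beyond the scatter is therefore expected in this assay. The expected step is a 1.1-fold lower number from compound 3 to compound 4 (0.05 log units; within the scatter). Compound 4 is estimated at 30 nM, with an expected range of 9 nM to 100 nM.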

Compound 4, half-maximal inhibitory concentration in the A2780 assay: 770 nM
For compound 4 the middle estimate is 26-fold (1.41 log units) below the measured one; the whole stated range lies below it.
By their numbers in the A2780 assay, from the lowest: compounds 1 and 3 (each within the scatter of the next); then compounds 2 and 4 (each within the scatter of the next).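

In the A2780 assay, ethyl does not match 1-methylpyrrolidin-2-yl on this carbonyl carbon, with a 23-fold higher number from compound 3 to compound 4 (1.36 log units; beyond the scatter), and it stays level with oxan-4-yl, with a 1.5-fold higher number from compound 2 to compound 4 (0.19 log units; within the scatter); among compounds 2, 3 and 4, only compound 3 gives the low number. With ethyl held fixed, the A2780 assay shows a 31-fold higher number from compound 1 to compound 4 (1.49 log units; beyond the scatter) for amino in place of hydrogen on an aromatic carbon. The value of compound 1 does not carry over to the amino-bearing compounds. In a physicochemical assay for solubility, read by LC-MS, in phosphate buffer, with a stated time of 24 h, at pH 6.8 (on this read-out higher numbers stand for higher solubility and lower numbers for lower solubility), compound 3 gives 820000 nM and compound 4 gives 230000 nM. The same ethyl change also separates the compounds in the physicochemical assay: the measured solubility of compound 3, 820000 nM, and of compound 4, 230000 nM, a 3.6-fold lower number (0.55 log units; beyond the scatter)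

As far as these compounds go, whether an open-chain amine or pyrrolidin-2-yl on this carbonyl carbon would match 1-methylpyrrolidin-2-yl remains open. So does the effect of the opposite stereocentre in that group.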